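A hydroxy group on the pentyl chain of compound 3

This account rests on a few compounds, and the source may have more. Where it says the series, first, only, none or still open, it means among the compounds named here.

Compound 3 `CCCCCC12CCC(c3nnc(-c4ccccc4C(F)(F)F)n3C)(CC1)CC2` carries a plain pentyl chain on its shared core. Going by the values given here, in an assay on CHO-K1 cells for inhibition of 11-beta-hydroxysteroid dehydrogenase type 2 (Homo sapiens), read by scintillation proximity assay (a higher number here means a weaker inhibitor, a lower number a stronger inhibitor), compound 3 gives 1300 nM, the only true number among the three measured compounds. Compound 1 `Cn1c(-c2ccccc2C(F)(F)F)nnc1C12CCC(CCS(=O)(=O)C(C)(C)C)(CC1)CC2` reaches only the limit > 4000 nM in this assay. Compound 2 `CC(C)S(=O)(=O)CCC12CCC(c3nnc(-c4ccccc4C(F)(F)F)n3C)(CC1)CC2` likewise reaches only the limit > 4000 nM. the limit of > 4000 nM in this assay, at which 2 of the 3 values shown sit, marks where those two sit. The steps of an at least 3.0-fold lower number from compound 1 to compound 3 (0.48 log units; beyond the scatter) and an at least 3.0-fold lower number from compound 2 to compound 3 (0.48 log units; beyond the scatter) both run from a sulfonyl-bearing chain to a plain propyl end, and both are beyond the scatter in the same direction. Compound 4 `CC(O)CCCC12CCC(c3nnc(-c4ccccc4C(F)(F)F)n3C)(CC1)CC2` is not yet measured; it differs from compound 3 by hydroxy in place of hydrogen on a saturated chain carbon bound to two saturated chain carbons. Both measured steps show that a sulfonyl group on the chain went with a limit and a plain alkyl chain with a number, so the hydroxy group in compound 4 is expected to weaken inhibition, though less than a sulfonyl group did. Compound 4 is therefore expected to give 3000 nM, between 1200 nM and 8000 nM. The expected step is a 2.3-fold higher number from compound 3 to compound 4 (0.36 log units; beyond the scatter), a weakening that may just exceed the scatter.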

Compound 4, half-maximal inhibitory concentration: > 1000 nM
Compound 4: a limit, no number; the forecaster's own chance of this, stated with the estimate: 35%; the middle value does not contradict the limit.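

In this assay compound 4 gives > 1000 nM, which is a limit and not a number. The steps to compound 4 from compound 1, compound 2 and compound 3 cannot be read. The compounds shown leave open whether, and how far, the hydroxy group changes inhibition relative to compound 3.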